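Working notes: methoxy placement and cytotoxicity in a small series

The compounds below may be only part of what the source reports. "The series", "measured", "known", "first", "only" and "open" are said of these compounds alone.

Measured so far in a functional assay on HCT-116 cells (Homo sapiens) for cytotoxicity, read by MTT assay, with a stated time of 72 h; a lower number here means a stronger inhibitor, a higher number a weaker inhibitor:
compound 1 `Cc1c(/N=C/c2ccc(N(C)C)cc2)c(=O)n(-c2ccccc2)n1C` gives 832000000 nM
compound 2 `COc1ccc(/C=N/c2c(C)n(C)n(-c3ccccc3)c2=O)cc1` gives 575000000 nM
compound 3 `COc1ccc(/C=N/c2c(C)n(C)n(-c3ccccc3)c2=O)cc1OC` gives 575000000 nM

Compound 2 stands level with compound 3 at the digits shown, the two together holding the lowest numbers of the three, and compound 1 sits within the scatter of both. The two measured steps, a 1.4-fold lower number from compound 1 to compound 2 (0.16 log units; within the scatter) and no change at the digits printed from compound 2 to compound 3 (within the scatter), both stay within the scatter. Compound 4 `COc1ccccc1/C=N/c1c(C)n(C)n(-c2ccccc2)c1=O` differs from compound 2 by 2-methoxyphenyl in place of 4-methoxyphenyl on a carbon with a double bond to nitrogen. Going by the values given here, no measured step moves a group to another place on that ring, so the closest guidance is that neither change tried so far shifted this assay beyond the scatter. Compound 4 is therefore expected to show no step beyond the scatter, a 1.0-fold higher number from compound 2 to compound 4 (0.02 log units; within the scatter). Compound 4 is estimated at 600000000 nM, within 300000000 nM to 1200000000 nM.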

Compound 4, half-maximal inhibitory concentration: 324000000 nM
For compound 4 the middle estimate is 1.9-fold (0.27 log units) above the measured one; the measured number falls inside the stated range.
By their numbers in this assay, from the lowest: compounds 4, 2, 3 and 1 (each within the scatter of the next, the first and the last beyond it).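

In this assay, 2-methoxyphenyl in place of 4-methoxyphenyl on a carbon with a double bond to nitrogen gives a 1.8-fold lower number from compound 2 to compound 4 (0.25 log units; within the scatter). Going by these compounds alone, this is the first step that moves a group to another place on that ring, and it stays within the scatter, so the assay does not separate these two placements. No available evidence bears on this step.

From the compounds shown here alone, whether a hydroxyl, a carboxylic acid or a longer alkoxy chain on that ring would shift the number beyond the scatter remains open.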